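Aryl replacement on the shared core: compound 1 to compound 4

The source may hold more compounds than are shown below. What is called first, only, known or untested is meant among the compounds shown, and "the series" means these compounds.

Compound 1 `CCOC(=O)c1cnn(-c2nc(-c3ccccc3Cl)c(C#N)c(=O)n2C)c1N` is read in a functional assay, with a stated time of 20 min (a lower number here means a stronger inhibitor, a higher number a weaker inhibitor), at 78 ug/mL. Two further compounds carry a dimethylaminophenyl group on the shared core: compound 2 `CSc1nc(-c2ccc(N(C)C)cc2)c(C#N)c(=O)n1C` gives 78 ug/mL in this assay, and compound 3 `CN(C)c1ccc(-c2nc(NN)n(C)c(=O)c2C#N)cc1` gives 81 ug/mL in this assay. Compound 1 stands level with compound 2 at the digits reported; together the two hold the lowest of the three numbers, and the gap from either to compound 3 is within the scatter, so no ordering can be drawn among them. Going by the values given here, the only single-point change measured so far, a 1.0-fold higher number from compound 2 to compound 3 (0.02 log units; within the scatter), also lies within the scatter.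

Compound 4 `CCOC(=O)c1cnn(-c2nc(-c3cccc(OC)c3OC)c(C#N)c(=O)n2C)c1N` differs from compound 1 in one place: 2,3-dimethoxyphenyl in place of 2-chlorophenyl on an aromatic carbon. The measured step of a 1.0-fold higher number from compound 2 to compound 3 (0.02 log units; within the scatter) alters a different position on the shared core, not the aryl group, so it has no direct bearing on this change. What the series does show is that all three measured values in this assay sit within the scatter of one another, whatever the substituent. The expected step of no change at the digits printed from compound 1 to compound 4 (within the scatter) is therefore none beyond the scatter. Compound 4 is estimated at 78 ug/mL, with a range from 35 ug/mL to 170 ug/mL in this assay.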

Compound 4, half-maximal inhibitory concentration: 54 ug/mL
Compound 4: middle estimate off by 1.4-fold (0.16 log units), on the high side, and the stated range covers the measured number.
By their numbers in this assay, from the lowest: compounds 4, 1, 2 and 3 (each within the scatter of the next).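

The aryl position of the shared core now has its first measured single change: in this assay, 2,3-dimethoxyphenyl in place of 2-chlorophenyl gives a 1.4-fold lower number from compound 1 to compound 4 (0.16 log units; within the scatter) and separates neither compound from the other. The swap removes the chlorine and brings in a larger group with hydrogen-bond acceptors, yet the two numbers stay within the scatter of each other, so neither this loss nor this gain registers as a resolved difference in this read-out. No measured information is available to explain this outcome.

No single change at this position in the compounds shown reaches beyond the scatter, so it remains open whether the aryl group can influence the read-out in this assay at all. Also open, from the compounds shown here alone, is whether an aryl group carrying an amine or a carboxylic acid, or a cyclohexyl group in place of the aryl ring, would give a number that stands clear of the scatter around compound 1 and compound 4.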